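Swapping methyl for methoxy on the amide-side benzyl ring

The source may report more compounds than this note shows. Statements on the series, on what has been measured and on what is new or still open speak of the compounds shown alone.

Measured in an assay on microsomes from liver for inhibition of 3-hydroxy-3-methylglutaryl-coenzyme A reductase (Rattus norvegicus), read by scintillation counting, with stated times of 0.5 h and 0.75 h; on this read-out lower numbers stand for stronger inhibition and higher numbers for weaker inhibition:
compound 1 `O=C(O)C[C@H](O)C[C@H](O)CCn1c(-c2ccc(F)cc2)nc(C(=O)NCc2ccccc2F)c1C1CC1` gives 1.5 nM
compound 2 `Cc1ccc(CNC(=O)c2nc(-c3ccc(F)cc3)n(CC[C@@H](O)C[C@@H](O)CC(=O)O)c2C2CC2)cc1` gives 1.7 nM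
compound 3 `Cc1c(C(=O)NCc2ccccc2)nc(-c2ccc(F)cc2)n1CC[C@@H](O)C[C@@H](O)CC(=O)O` gives 94 nM

Compound 2 stands within the scatter of compound 1, while compound 3 shows a much higher number; compound 3 differs from compound 2 in more than one place, so only its value can be compared. Compound 4 `COc1ccc(CNC(=O)c2nc(-c3ccc(F)cc3)n(CC[C@@H](O)C[C@@H](O)CC(=O)O)c2C2CC2)cc1` differs from compound 2 by methoxy in place of methyl on an aromatic carbon. Among the compounds with values here, the only measured step that alters this ring, a 1.1-fold higher number from compound 1 to compound 2 (0.05 log units; within the scatter), was small. A second small substituent change on the same ring is therefore expected to move the number in this assay little, in no clear direction beyond the scatter. Compound 4 is estimated at 2 nM, with a range of 1 nM to 4 nM. The expected step is a 1.2-fold higher number from compound 2 to compound 4 (0.07 log units; within the scatter).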

Compound 4, half-maximal inhibitory concentration: 1.2 nM
For compound 4 the middle estimate is 1.7-fold (0.22 log units) above the measured one, and the stated range covers the measured number.
By their numbers in this assay, from the lowest: compounds 4, 1 and 2 (each within the scatter of the next); then compound 3.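

In this assay, within the data shown here, methoxy in place of methyl gives a 1.4-fold lower number from compound 2 to compound 4 (0.15 log units; within the scatter) and 4-methoxyphenyl in place of 2-fluorophenyl gives a 1.3-fold lower number from compound 1 to compound 4 (0.10 log units; within the scatter) so this ring can now be seen to carry a group with an oxygen atom, a hydrogen-bond acceptor, with no step leaving the scatter. Nothing measured here explains why the number holds so steady. Still open, from the compounds shown here alone, is whether an amine or a carboxylic acid on this ring, or a longer chain such as butoxy in place of methoxy, would keep the number this low.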